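Cytotoxicity notes on a cinnamoyl hydrazide pair and a nitro analogue

A few compounds are considered here, and "the series" means these few. Any claim that something is new, unique, unknown or untested is made for them only; others in the source may bear on it.

Measured compounds:
compound 1, `O=C(/C=C/c1cccc(Br)c1)NNC(=O)c1ccc2c(c1)OCCO2`, 351000 nM
compound 2, `O=C(/C=C/c1cccc(Cl)c1)NNC(=O)c1ccc2c(c1)OCCO2`, 391000 nM

Both compounds share the same core and differ only in the halogen on the phenyl ring. In an ADME assay on cells (Macrophage) for cytotoxicity, read by MTT assay, with a stated time of 24 h (a higher number here means that more compound is tolerated, a lower number that less compound is tolerated), compound 1 gives 351000 nM and compound 2 gives 391000 nM. Within the data shown here, the only measured step, a 1.1-fold higher number from compound 1 to compound 2 (0.05 log units; within the scatter), is within the scatter, so compound 2 sits alongside compound 1 with no separation that the assay can resolve.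

Compound 3, `O=C(/C=C/c1ccccc1[N+](=O)[O-])NNC(=O)c1ccc2c(c1)OCCO2`, has not been measured in this assay. The change is 2-nitrophenyl in place of 3-chlorophenyl on a double-bonded chain carbon bound to a double-bonded chain carbon. Among the measured compounds shown here, no measured step exchanges a halogen for a nitro group, and none moves a substituent to a different position on the ring, so the one step in hand bears on this change only in showing that a small exchange at this ring left this assay essentially unmoved. The expectation is therefore a step no larger than the scatter, with a slight lean toward less compound being tolerated, expressed as a 1.2-fold lower number from compound 2 to compound 3 (0.07 log units; within the scatter). Compound 3 is estimated at 330000 nM, with a range from 150000 nM to 700000 nM.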

Compound 3, half-maximal cytotoxic concentration: 257000 nM
For compound 3 the middle estimate is 1.3-fold (0.11 log units) above the measured one; the measured number falls inside the stated range.
By their numbers in this assay, from the lowest: compounds 3, 1 and 2 (each within the scatter of the next).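

At the aryl group on the double-bonded chain carbon, this assay now covers an exchange of the whole substituted ring and not only of its halogen: 2-nitrophenyl in place of 3-chlorophenyl reads as (a 1.5-fold lower number from compound 2 to compound 3 (0.18 log units; within the scatter)), and 2-nitrophenyl in place of 3-bromophenyl reads as (a 1.4-fold lower number from compound 1 to compound 3 (0.14 log units; within the scatter)). Both steps are within the scatter, so this place on the chain has now taken a halogen exchange and an exchange of substituent and ring position without any separation that the assay can resolve. That holds even though the entering 2-nitrophenyl brings 2 hydrogen-bond acceptors and 1 double bond outside aromatic rings, none of which the leaving halogenated groups carry. Nothing measured here speaks to the reason for these numbers.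

On these data alone, the nitro group and the new ring position enter together in one step, so their separate contributions remain open. Also open, as far as these compounds go, is whether a group of another kind on this ring, such as an amine or a carboxylic acid, would give a step beyond the scatter in this assay.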